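This account rests on a few compounds, and the source may have more. Where it says the series, first, only, none or still open, it means among the compounds named here.

Working notes on the aryl swap at the carbon with a double bond to nitrogen.

Three compounds share the core and differ only in the aryl group there. Compound 1 `CN(C)CCn1cnnc1-c1cc(Oc2ccc(NC(=O)N/N=C/c3c(Cl)cccc3Cl)cc2F)ccn1` carries a 2,6-dichlorophenyl and, in a functional assay on NCI-H460 cells (Homo sapiens) for cytotoxicity, read by MTT assay, with a stated time of 72 h (a lower number here means a stronger inhibitor, a higher number a weaker inhibitor), compound 1 gives 350 nM. Compound 2 `CN(C)CCn1cnnc1-c1cc(Oc2ccc(NC(=O)N/N=C/c3ccccc3O[N+](=O)[O-])cc2F)ccn1` carries a 2-(nitrooxy)phenyl and in this assay compound 2 gives 1270 nM. Compound 3 `CN(C)CCn1cnnc1-c1cc(Oc2ccc(NC(=O)N/N=C/c3ccc(O)c(O)c3)cc2F)ccn1` carries a 3,4-dihydroxyphenyl and in this assay compound 3 gives 1930 nM. Compound 1 stands with the lowest number of the three: the step of a 3.6-fold higher number from compound 1 to compound 2 (0.56 log units; beyond the scatter) and the step of a 5.5-fold higher number from compound 1 to compound 3 (0.74 log units; beyond the scatter) both lie beyond the scatter, whereas the step of a 1.5-fold higher number from compound 2 to compound 3 (0.18 log units; within the scatter) lies within it.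

Compound 4 `CN(C)CCn1cnnc1-c1cc(Oc2ccc(NC(=O)N/N=C/c3ccc(Cl)cc3)cc2F)ccn1` is not yet measured. Relative to compound 1 the change is 4-chlorophenyl in place of 2,6-dichlorophenyl on a carbon with a double bond to nitrogen. Both measured departures from the 2,6-dichlorophenyl of compound 1 raised the number by a modest amount, so a step in the same direction is expected here, likely smaller since one chlorine on the ring remains. The step from compound 1 to compound 4 is estimated at a 2.0-fold higher number from compound 1 to compound 4 (0.30 log units; within the scatter). Compound 4 is therefore expected to give about 700 nM in this assay, with a range from 300 nM to 1600 nM.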

Compound 4, half-maximal inhibitory concentration: 320 nM
Compound 4: the middle estimate sits 2.2-fold (0.34 log units) above what was measured, within the range that was stated.
By their numbers in this assay, from the lowest: compounds 4 and 1 (each within the scatter of the next); then compounds 2 and 3 (each within the scatter of the next).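

In this assay, 4-chlorophenyl and 2,6-dichlorophenyl cannot be told apart on the carbon with a double bond to nitrogen, with a 1.1-fold lower number from compound 1 to compound 4 (0.04 log units; within the scatter) lying within the scatter, so among these two compounds the 2,6-dichloro pattern is not needed to hold the number of compound 1. The separation from the non-chlorinated aryl groups also survives the loss of a chlorine, with a 6.0-fold lower number from compound 3 to compound 4 (0.78 log units; beyond the scatter) and a 4.0-fold lower number from compound 2 to compound 4 (0.60 log units; beyond the scatter) both beyond the scatter, so the four compounds fall into two groups: the chlorophenyl pair, compounds 1 and 4, and compounds 2 and 3, which carry 2-(nitrooxy)phenyl and 3,4-dihydroxyphenyl. No supporting data are available to explain this split between the two groups.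

The compounds shown do not settle whether chlorine itself matters at this position, and an unsubstituted phenyl, or a ring bearing bromine or a methoxy group, would test that directly. On these data alone, how a ring carrying an amine or a carboxylic acid would behave at this carbon also remains open.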